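A few compounds are considered here, and "the series" means these few. Any claim that something is new, unique, unknown or untested is made for them only; others in the source may bear on it.

In an ADME assay on GES1 cells (Homo sapiens) for inhibition, read by MTT assay, with a stated time of 72 h (a lower number here means a stronger inhibitor, a higher number a weaker inhibitor), compound 1 `Cc1cc(Nc2cc(-c3ccccc3)[nH]n2)n2nc(SCc3c(Cl)cccc3Cl)nc2n1` gives 39600 nM. Compound 2 `Cc1cc(Nc2ccn(Cc3cccc4ccccc34)n2)n2nc(SCc3ccc(Br)cc3)nc2n1` gives 30000 nM, and these two numbers lie within the scatter of each other, so neither is placed ahead of the other. Compound 3 `Cc1cc(Nc2cc(-c3ccccc3)[nH]n2)n2nc(SCC3CCCCC3)nc2n1` is reported only as a limit, > 50000 nM.

The step under consideration leads to compound 4 `Cc1cc(Nc2cc(-c3ccccc3)[nH]n2)n2nc(SCc3cccc(Br)c3)nc2n1`. The structural change is 3-bromophenyl in place of 2,6-dichlorophenyl on a saturated chain carbon bound to a sulfur. The aromatic ring of carbon stays, and only its substituents differ.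

One measured step changes the same place: an at least 1.2-fold higher number from compound 1 to compound 3 (0.10 log units; that floor lies within the scatter), with cyclohexyl entering in place of 2,6-dichlorophenyl. Its size is bounded on one side only, so it is a weak guide. No step beyond the scatter is expected in this assay because an at least 1.2-fold higher number from compound 1 to compound 3 (0.10 log units; that floor lies within the scatter) gives no evidence of a real change at this place.

The expected step is a 1.1-fold lower number from compound 1 to compound 4 (0.05 log units; within the scatter), which would stay within the scatter. A report of compound 4 as a limit would also not be surprising. For compound 4 the estimated value is 35000 nM, with an expected range of 18000 nM to 50000 nM.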

Compound 4, half-maximal inhibitory concentration: > 50000 nM
Compound 4 was reported as a limit; the forecaster's own chance of this, stated with the estimate: 35%; at least 1.4-fold (0.15 log units) between middle value and limit.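

In this assay, on these data alone, 3-bromophenyl in place of 2,6-dichlorophenyl on a saturated chain carbon bound to a sulfur gives an at least 1.2-fold higher number from compound 1 to compound 4 (0.10 log units; that floor lies within the scatter) and so shows no real change at this place, although the true size of the step stays unknown. With the aromatic ring of carbon kept, the outcome is of the same kind as with cyclohexyl in compound 3, so a second group at this place, this time aromatic, also gives no step beyond the scatter, and the step from compound 3 to compound 4 cannot be read. Compound 3 and compound 4 are both reported as limits, not as numbers: the limit of > 50000 nM in this assay, at which 2 of the 4 values shown sit.

As far as these compounds go, how far compound 3 and compound 4 lie past that limit remains open, as does any order of the two. Also open, from the compounds shown here alone, is whether a different group on this carbon would give a clearly lower number in this assay than compound 1, for example a benzyl ring carrying an amine or a carboxylic acid, or a longer chain in place of cyclohexyl.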